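Removing the Methoxy Group from Compound 3

A few compounds are considered here, and "the series" means these few. Any claim that something is new, unique, unknown or untested is made for them only; others in the source may bear on it.

Compound 3 (`COc1cccc(/C=C/C(=O)c2sc(Nc3ccccc3)nc2C)c1`) carries an unsubstituted phenyl on the nitrogen attached to the shared core. In a functional assay on PC-3 cells (Homo sapiens) for cytotoxicity, read by MTT assay (a lower number here means a stronger inhibitor, a higher number a weaker inhibitor), compound 3 gives > 25000 nM, which is a limit of the assay and not a number. Compound 1 (`COc1cccc(/C=C/C(=O)c2sc(Nc3cccc(C)c3)nc2C)c1`) in this assay gives > 25000 nM, again a limit. Compound 2 (`COc1cccc(/C=C/C(=O)c2sc(Nc3ccc(Cl)cc3)nc2C)c1`) in this assay gives > 25000 nM, also a limit. All three compounds thus sit at the limit of > 25000 nM in this assay, at which 3 of the 3 values shown sit, and the steps a step that the two limits leave unreadable from compound 1 to compound 2, a step that the two limits leave unreadable from compound 1 to compound 3 and a step that the two limits leave unreadable from compound 2 to compound 3 cannot be read from them. Compound 4 (`Cc1nc(Nc2ccccc2)sc1C(=O)/C=C/c1ccccc1`) differs from compound 3 in hydrogen in place of methoxy on an aromatic carbon. Within the data shown here, none of the measured steps touches this part of the molecule, and all of them are unreadable, so they give no size for the step in this assay in either direction. Compound 4 is expected to remain at the limit, so the step from compound 3 to compound 4 is estimated as a step that the limit leaves unreadable from compound 3 to compound 4. Compound 4 is expected to give about 40000 nM in this assay, within a range from 15000 nM to 150000 nM.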

Compound 4, half-maximal inhibitory concentration: > 25000 nM
Compound 4: no number, only a limit (the forecaster's own chance of this, stated with the estimate: 85%); the middle value lies beyond the limit too.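

With compound 3 and compound 4 both standing at a limit of the assay and not at a number, no step can be read between them in this assay. The compounds shown leave open how large any of these single changes is, and which change, if any, would bring a value inside the limit.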